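This account rests on a few compounds, and the source may have more. Where it says the series, first, only, none or still open, it means among the compounds named here.

Compound 1 `Nc1ccc(N2CCN(CCC(=O)c3csc4ccccc34)CC2)cc1`: 14100 nM
Compound 2 `N#Cc1ccc(N2CCC(NCCC(O)c3csc4ccccc34)CC2)cc1`: 1660 nM
Compound 3 `N#Cc1ccc(N2CCC(NCCC(=O)c3csc4ccccc34)CC2)cc1`: 7240 nM

In an assay on HEK293 cells for displacement of a labelled ligand from 5-hydroxytryptamine receptor 7 (Homo sapiens), read by scintillation counting, with a stated time of 1 h (a higher number here means a weaker inhibitor, a lower number a stronger inhibitor), compound 1 gives the highest of these three numbers. Compound 3 sits nearest to it, within the usual scatter, so the two cannot be told apart; compound 2 lies furthest away, beyond the scatter. Compound 4 `O=C(CCN1CCN(c2ccc([N+](=O)[O-])cc2)CC1)c1csc2ccccc12` has not yet been measured. It differs from compound 1 in one place: nitro in place of amino on an aromatic carbon. Within the data shown here, no pair among the measured compounds shows this same change, so there is no measured step to lean on. The shared core and the chain stay unchanged, and the step is expected to remain within the scatter, with no clear direction. The step expected from this change is a 1.4-fold lower number from compound 1 to compound 4 (0.15 log units; within the scatter). For compound 4 in this assay the estimate is 10000 nM, expected between 3000 nM and 35000 nM.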

Compound 4, inhibition constant: > 100000 nM
Compound 4 ended at the assay's limit (the forecaster's own chance of this, stated with the estimate: 10%); middle value at least 10-fold (1.00 log units) away from the limit.
By their numbers in this assay, from the lowest: compound 2; then compounds 3 and 1 (each within the scatter of the next). At a limit, above all of these: compound 4.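

Among these compounds, changing 4-aminophenyl to 4-nitrophenyl gives the only measured step at this position, and in this assay it reads as an at least 7.0-fold higher number from compound 1 to compound 4 (0.85 log units; beyond the scatter). This position is therefore sensitive to the group it carries: with nitro in place of amino, the compound is a clearly weaker inhibitor. The value for compound 4 is a limit of the assay, not a number: the limit of > 100000 nM in this assay, at which 1 of the 4 values shown sits.

Going by these compounds, whether the loss comes from adding nitro or from removing amino remains open. A plain hydrogen, a methoxy group or a carboxylic acid at this place could help separate the two.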